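Methyl on the phenoxy ring in a pyrrolidine acid series

A few compounds are considered here, and "the series" means these few. Any claim that something is new, unique, unknown or untested is made for them only; others in the source may bear on it.

Measured so far in a functional assay on cells for agonist activity at Free fatty acid receptor 1 (Mus musculus), read by FLIPR and calcium flux, with a stated time of 100 s; on this read-out lower numbers stand for an effect already at smaller amounts and higher numbers for an effect only at larger amounts of compound:
compound 1 `O=C(O)C[C@@H]1CCCN1c1ccc(OCc2ccc(Cl)cc2Cl)cc1`, 4500 nM
compound 2 `O=C(O)C[C@H]1CCCN1c1ccc(OCc2ccc(Cl)cc2Cl)cc1`, > 17000 nM
compound 3 `Cc1ccccc1COc1ccc(N2CCC[C@H]2CC(=O)O)cc1`, 3400 nM

Compound 2 gives only a limit of this assay, > 17000 nM, and no number. Among the two numbers, compound 3 has the lower one, but its nearest neighbour compound 1 sits within the scatter of it, so no order is claimed between them (a 1.3-fold lower number from compound 1 to compound 3 (0.12 log units; within the scatter)). Going by the values given here, the one step beyond the scatter is an at least 3.7-fold higher number from compound 1 to compound 2 (0.57 log units; beyond the scatter), which rests on the fact that compounds 1 and 2 differ only in the configuration as drawn and on (the limit of > 17000 nM in this assay, at which 1 of the 3 values shown sits).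

Compound 4 `Cc1ccccc1COc1ccc(N2CCC[C@H]2CC(=O)O)cc1C` differs from compound 3 by methyl in place of hydrogen on an aromatic carbon. Among the compounds with values here, no measured step touches this ring position: the step from compound 1 to compound 3 swaps the aryl group on the chain carbon bound to the ether oxygen and stays within the scatter, and the step from compound 1 to compound 2 concerns configuration alone. A small methyl entering on the aromatic ring that carries the pyrrolidine nitrogen is therefore expected to give a step in this assay of no more than the scatter, in either direction.

Compound 4 is estimated at 3000 nM, with a range from 1000 nM to 9000 nM, the expected step being a 1.1-fold lower number from compound 3 to compound 4 (0.05 log units; within the scatter).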

Compound 4, half-maximal effective concentration: > 33000 nM
Compound 4 ended at the assay's limit; the forecaster's own chance of this, stated with the estimate: 10%; at least 11-fold (1.04 log units) between middle value and limit.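

Methyl in place of hydrogen on this aromatic carbon, ortho to a group of 9 heavy atoms and meta to a group of 9 heavy atoms, gives in this assay an at least 9.7-fold higher number from compound 3 to compound 4 (0.98 log units; beyond the scatter). A single added carbon here therefore does what the exchange of the whole aryl group on the chain carbon did not do, since that exchange stayed within the scatter: a 1.3-fold lower number from compound 1 to compound 3 (0.12 log units; within the scatter). Compound 4 gives > 33000 nM, which is a limit of the assay and not a number, so the step has a lower bound and no measured size: the limit of > 33000 nM in this assay, at which 1 of the 4 values shown sits.

Open, going by these compounds, is whether this result belongs to methyl alone or to any group on this aromatic carbon, and a fluorine, a hydroxyl or a methoxy group at the same place would separate the two. The compounds shown also give no reading of methyl on the remaining carbons of this ring, and they offer no cause for the step.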